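This account rests on a few compounds, and the source may have more. Where it says the series, first, only, none or still open, it means among the compounds named here.

The compounds measured so far, with their numbers in an ADME assay on HeLa cells (Homo sapiens) for cytotoxicity, read by sulforhodamine B assay, with a stated time of 48 h, tested at 10 uM; on this read-out lower numbers stand for less inhibition and higher numbers for more inhibition at the one concentration tested (going by the name of the read-out):

Compound 1, `COc1nc2ccc(Br)cc2cc1C(c1ccccc1)n1cc(-c2ccc(Br)cc2)nn1`: 6.92%
Compound 2, `COc1nc2ccc(Br)cc2cc1C(c1ccccc1)n1cc(-c2ccccc2)nn1`: 13.9%
Compound 3, `COc1nc2ccc(Br)cc2cc1C(c1ccccc1)n1cc(CCCO)nn1`: 11.3%

All three share one core and differ only in the group carried on the triazole ring. In this assay the three numbers sit close together: compound 3 is nearest to compound 2, with a step of a number 2.6 percentage points lower from compound 2 to compound 3 (within the scatter), and furthest from compound 1, with a step of a number 4.4 percentage points higher from compound 1 to compound 3 (within the scatter), and both gaps fall within the usual scatter, so no ordering of the three can be read from them.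

Compound 4, `COc1nc2ccc(Br)cc2cc1C(c1ccccc1)n1cc(CCO)nn1`, is the next compound to be measured. It is compound 3 with a shorter chain: hydroxy in place of hydroxymethyl on a saturated chain carbon, two bonds along the chain from an aromatic carbon. For the measured compounds named here, the only steps that bear on this change are those that swap the whole group on the triazole, a number 4.4 percentage points higher from compound 1 to compound 3 (within the scatter) and a number 2.6 percentage points lower from compound 2 to compound 3 (within the scatter), and neither moved the number beyond the scatter. A much smaller change, trimming one carbon from the chain, is therefore expected to leave the number where it is. The expected step is a number 0.3 percentage points lower from compound 3 to compound 4 (within the scatter). Compound 4 is estimated at 11% in this assay, with a range from 3% to 19%.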

Compound 4, a percentage reported as inhibition, at one concentration (the size of the read-out at that concentration, not a potency): 0.85%
Compound 4: middle estimate off by 10.2 percentage points, on the high side; measured number below the stated range.
By their numbers in this assay, from the lowest: compounds 4, 1, 3 and 2 (each within the scatter of the next, the first and the last beyond it).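

Unlike the steps among compounds 1, 2 and 3, the change at this position in this assay gives a number 10.5 percentage points lower from compound 3 to compound 4 (beyond the scatter) from the loss of a single chain carbon, so the length of the chain carrying the hydroxy can matter even though the group swaps seen earlier did not move the number past the scatter. The 2-hydroxyethyl group also separates from phenyl, with a number 13.1 percentage points lower from compound 2 to compound 4 (beyond the scatter) as the step, but not from 4-bromophenyl, where a number 6.1 percentage points lower from compound 1 to compound 4 (within the scatter) leaves the two compounds indistinguishable, so a short hydroxy chain is not set apart from the aromatic groups as a class. No measurement shown gives a reason for this shift.

Going by these compounds, two chain lengths cannot show a trend, so it remains open whether the number would stay low or rise again with a hydroxymethyl group on the triazole or with a longer chain such as 4-hydroxybutyl. On these data alone, it is also open whether the hydroxy itself plays any part in the step, which an amine, a methyl ether or a carboxylic acid at the end of the same chain could test.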